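The source may report more compounds than this note shows. Statements on the series, on what has been measured and on what is new or still open speak of the compounds shown alone.

Compound 2 `Cc1nc(-c2ccccc2)c(C(=O)N2CCN(c3ccccc3)CC2)o1`: 39.1 nM
Compound 1 `COc1cc(OC)cc(N2CCN(C(=O)c3sc(C)nc3-c3ccccc3F)CC2)c1`: 96.8 nM
Compound 3 `CCc1nc(-c2ccc(F)cc2)c(C(=O)N2CCN(c3cccc(OC)c3)CC2)o1`: 411 nM

In a functional assay on HL-60 cells (Homo sapiens) for inhibition, read by MTT assay, with a stated time of 72 h (on this read-out lower numbers stand for stronger inhibition and higher numbers for weaker inhibition), compound 2 gives the lowest number of the three, with compound 1 next and compound 3 furthest away; both gaps lie beyond the usual scatter, so compound 2 is the most potent here. Compound 4 `Cc1nc(-c2ccccc2)c(C(=O)N2CCN(c3cccc(Cl)c3)CC2)o1` is not yet measured. It differs from compound 2 in one place: chloro in place of hydrogen on an aromatic carbon, which reads as phenyl to 3-chlorophenyl. Among the measured compounds shown here, no single-change step between measured compounds exists to guide this, and compound 3, which also carries a group on that ring, differs in other places too. A small step is expected, a little toward weaker inhibition or none beyond the scatter, a 1.4-fold higher number from compound 2 to compound 4 (0.15 log units; within the scatter). Compound 4 is estimated at 55 nM, between 20 nM and 160 nM.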

Compound 4, half-maximal inhibitory concentration: 39.2 nM
The estimate for compound 4 lay 1.4-fold (0.15 log units) above the measured number; measured number inside the range.
By their numbers in this assay, from the lowest: compounds 2 and 4 (each within the scatter of the next); then compound 1; then compound 3.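

In this assay the step is a 1.0-fold higher number from compound 2 to compound 4 (0.00 log units; within the scatter), so compound 2 and compound 4 cannot be told apart. Among the compounds shown here, this gives the first comparison in which only one place differs, and it shows that 3-chlorophenyl reads the same as phenyl on this side of the molecule. Nothing measured here explains this result. On these data alone, it remains open whether an amine or a carboxylic acid at this same place would also read the same, and whether chloro would do so elsewhere on this ring.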